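A few compounds are considered here, and "the series" means these few. Any claim that something is new, unique, unknown or untested is made for them only; others in the source may bear on it.

Compound 1 `O=C1/C(=C/c2ccc(F)cc2)CCC/C1=C\c1ccccc1[N+](=O)[O-]`: 3000 nM
Compound 2 `COc1cc(/C=C2\CCC/C(=C\c3ccccc3[N+](=O)[O-])C2=O)cc(OC)c1OC`: 3000 nM

In a functional assay on HL-60 cells (Homo sapiens) for cytotoxicity, with a stated time of 24 h (on this read-out lower numbers stand for higher toxicity in this test and higher numbers for lower toxicity in this test), compound 2 gives 3000 nM. It stands level with compound 1 at 3000 nM, and the two cannot be told apart within the scatter. The next compound to be tested is compound 3 `COc1cc(/C=C2\CCC/C(=C\c3cccc([N+](=O)[O-])c3)C2=O)cc(OC)c1OC`, which differs from compound 2 by a single change, 3-nitrophenyl in place of 2-nitrophenyl on a double-bonded chain carbon bound to a double-bonded ring carbon. Among the compounds with values here, no measured pair shows what this swap does, so the data offer no direct guide to its size or direction. The expectation therefore starts from compound 2 at 3000 nM and assumes no clear shift either way. The expected change, a 1.2-fold lower number from compound 2 to compound 3 (0.08 log units; within the scatter), is an estimate that stays within the scatter. Compound 3 is estimated at 2500 nM, with an expected range from 800 nM to 8000 nM.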

Compound 3, half-maximal cytotoxic concentration: 59000 nM
Beside the measured number, compound 3's estimate is 24-fold (1.37 log units) below it; the whole stated range lies below it.
By their numbers in this assay, from the lowest: compounds 1 and 2 (each within the scatter of the next); then compound 3.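

In this assay, the place on a double-bonded chain carbon bound to a double-bonded ring carbon proved highly sensitive to this change: 3-nitrophenyl in place of 2-nitrophenyl gives a 20-fold higher number from compound 2 to compound 3 (1.29 log units; beyond the scatter). Compounds 1 and 2 both carry 2-nitrophenyl, so they could not show this; the new pair shows that the two nitrophenyl groups, with the same atoms joined differently, are far from interchangeable here, and that the higher number means lower toxicity in this test. Nothing presented here gives a reason for the size of this step.

On these data alone, whether the same swap would have a similar effect with the other group of compound 1 remains open. So does how 4-nitrophenyl, or a phenyl ring carrying an amine, would read at this place.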